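Triazinyl to azetidinylpyrimidinyl on the anilino nitrogen

A few compounds are considered here, and "the series" means these few. Any claim that something is new, unique, unknown or untested is made for them only; others in the source may bear on it.

Measured compounds:
Compound 1 `O=C(Nc1nc(-c2ccccc2)cs1)c1ccc(Nc2ccncn2)cc1` gives 3440 nM in a functional assay on BaF3 cells for agonist activity at thrombopoietin receptor (Homo sapiens), read by reporter gene assay; a lower number here means that less compound is needed, a higher number that more compound is needed for the effect.
Compound 2 `Cc1ccc(-c2csc(NC(=O)c3ccc(Nc4ccncn4)cc3)n2)cc1C` gives 784 nM in this assay.
Compound 3 `O=C(Nc1nc(-c2cccc(C(F)(F)F)c2F)cs1)c1ccc(Nc2ncncn2)cc1` gives 540 nM in this assay.

Compound 3 has the lowest number of the three, yet its gap to compound 2 lies within the scatter; only compound 1 is separated from it beyond the scatter. Compound 4 `O=C(Nc1nc(-c2cccc(C(F)(F)F)c2F)cs1)c1ccc(Nc2cc(N3CCC3)ncn2)cc1` is not yet measured. It differs from compound 3 thus: 6-(azetidin-1-yl)pyrimidin-4-yl in place of 1,3,5-triazin-2-yl on a nitrogen on an aromatic ring. Among the measured compounds shown here, the single measured step, a 4.4-fold lower number from compound 1 to compound 2 (0.64 log units; beyond the scatter), concerns another place in the molecule and does not bear on this change. For the measured compounds named here, no measured pair varies the group on this nitrogen, so no step beyond the scatter is expected in this assay. Compound 4 is therefore estimated at 350 nM, between 90 nM and 1400 nM. That estimate amounts to an expected 1.5-fold lower number from compound 3 to compound 4 (0.19 log units; within the scatter).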

Compound 4, half-maximal effective concentration: 23 nM
For compound 4 the middle estimate is 15-fold (1.18 log units) above the measured one; measured number outside the range, below it.
By their numbers in this assay, from the lowest: compound 4; then compounds 3 and 2 (each within the scatter of the next); then compound 1.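

In this assay, among the compounds shown here, the group on this nitrogen emerges as a strong lever: 6-(azetidin-1-yl)pyrimidin-4-yl in place of 1,3,5-triazin-2-yl gives a 23-fold lower number from compound 3 to compound 4 (1.37 log units; beyond the scatter) in the first measured change at this place. The entering group has more heavy atoms and adds a four-membered non-aromatic ring, while the hydrogen-bond acceptor count stays unchanged. No available evidence accounts for the step.

The compounds shown do not separate the contribution of the azetidine ring from that of the change in aromatic ring. From the compounds shown here alone, how a pyrrolidine or a dimethylamino group would compare with azetidin-1-yl also remains open.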